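Chloro next to fluorosulfonyl: a second placement on a related core

A few compounds are considered here, and "the series" means these few. Any claim that something is new, unique, unknown or untested is made for them only; others in the source may bear on it.

Measured compounds:
Compound 1, `CC1(C)N=C(N)N=C(N)N1c1ccc(OCc2cccc(S(=O)(=O)F)c2)c(Cl)c1`, 7.72
Compound 2, `CC1(C)N=C(N)N=C(N)N1c1ccc(OCc2ccc(S(=O)(=O)F)cc2)c(Cl)c1`, 7.58
Compound 3, `CC1(C)N=C(N)N=C(N)N1c1ccc(OCc2ccc(Cl)c(S(=O)(=O)F)c2)c(Cl)c1`, 8

Of the compounds shown here, three have been tested in an assay on isolated protein for inhibition of Dihydrofolate reductase (Mus musculus); a higher number here means a more potent compound, by a factor of ten per unit of this negative logarithm, a lower number a less potent compound. Compound 1 gives 7.72, and compound 2, which has the same atoms joined differently, gives 7.58; the difference between the two cores is not broken down here. Compound 3 gives 8 in this assay. Going by the values given here, the single counted change from compound 1 to compound 3 is chloro in place of hydrogen on an aromatic carbon, and it produced a number 0.28 log units higher from compound 1 to compound 3 (within the scatter). Compound 2 shows the lowest of the three numbers, and compound 3 stands beyond the scatter above it.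

Compound 4, `CC1(C)N=C(N)N=C(N)N1c1ccc(OCc2ccc(S(=O)(=O)F)c(Cl)c2)c(Cl)c1`, has not yet been measured in this assay. Its difference from compound 2 is chloro in place of hydrogen on an aromatic carbon. Among the compounds with values here, this is the same kind of change as the one from compound 1 to compound 3, but not the same: in compound 3 the entering chloro is para to a large group, whereas in compound 4 it is meta to a large group.

Within the data shown here, because the only comparable step on record is a number 0.28 log units higher from compound 1 to compound 3 (within the scatter), a step of about the same size, a number 0.27 log units higher from compound 2 to compound 4 (within the scatter), is expected from compound 2 to compound 4 in this assay. On that basis compound 4 is estimated at 7.85, with a likely span from 7.45 to 8.25.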

Compound 4, logarithm of the reciprocal of the active concentration, log(1/C): 7.43
For compound 4 the middle estimate is 0.42 log units above the measured one, outside the stated range (below it).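

On the core of compound 2, chloro in place of hydrogen on an aromatic carbon, here ortho to a fluorosulfonyl group and meta to a large group, gives a number 0.15 log units lower from compound 2 to compound 4 (within the scatter). Set beside the earlier step, this shows that in this assay the change did not carry from one core to the other as a step of one fixed size: the same change on two cores in this assay, a number 0.28 log units higher (within the scatter) from compound 1 to compound 3 and a number 0.15 log units lower (within the scatter) from compound 2 to compound 4, 0.43 log units apart, beyond the scatter of two such steps Each step taken alone still lies within the scatter, so the pair does not show that chloro truly raises the number on one core and lowers it on the other, and it does not show which feature of the two cores separates the steps.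

With only two such pairs shown, it remains open whether a methyl, a methoxy or a nitrile entering at the same places would follow the step seen on one core, the step seen on the other, or neither. Also open, as far as these compounds go, is how the numbers on both cores would stand with a sulfonamide or a carboxylic acid in place of the fluorosulfonyl group.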